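Swapping 4-bromophenyl for 2-methoxyphenyl in the series

The compounds below may be only part of what the source reports. "The series", "measured", "known", "first", "only" and "open" are said of these compounds alone.

In a functional assay on SW-620 cells (Homo sapiens) for cytotoxicity, read by MTT assay, with a stated time of 72 h (on this read-out higher numbers stand for weaker inhibition and lower numbers for stronger inhibition), compound 1 (`COc1ccc(/C=C2\CCC/C(=C\c3cccc(OC)c3OC)C2=O)cc1OC`) gives 6400 nM and compound 2 (`COc1ccc(/C=C2\CCC/C(=C\c3ccc(Br)cc3)C2=O)cc1OC`) gives 5200 nM on the same read-out. Compound 2 cannot be told apart from compound 1, since the two numbers lie within the scatter of each other. For the measured compounds named here, no step between measured compounds that differ in one place is available, so these two values are the whole of the evidence.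

Compound 3 (`COc1ccccc1/C=C1\CCC/C(=C\c2ccc(OC)c(OC)c2)C1=O`) is still unmeasured. The change from compound 2 is 2-methoxyphenyl in place of 4-bromophenyl on a double-bonded chain carbon bound to a double-bonded ring carbon, with 2-methoxyphenyl in place of 4-bromophenyl on a double-bonded chain carbon bound to a double-bonded ring carbon. With compound 1 at 6400 nM and compound 2 at 5200 nM, nothing measured points to a shift in either direction in this assay for this change. The estimated step is a 1.1-fold higher number from compound 2 to compound 3 (0.02 log units; within the scatter) and is expected to stay within the scatter. For compound 3 the estimated value is 5500 nM, with an expected range from 2500 nM to 12000 nM when it is measured.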

Compound 3, half-maximal inhibitory concentration: 7800 nM
Compound 3: the middle estimate sits 1.4-fold (0.15 log units) below what was measured; the measured number falls inside the stated range.
By their numbers in this assay, from the lowest: compounds 2, 1 and 3 (each within the scatter of the next).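

Working notes on the series, in this assay: 2-methoxyphenyl in place of 4-bromophenyl on a double-bonded chain carbon bound to a double-bonded ring carbon now has a direct one-place reading (a 1.5-fold higher number from compound 2 to compound 3 (0.18 log units; within the scatter)), and this step stays within the scatter. A second one-place reading is now available, hydrogen in place of methoxy on an aromatic carbon (a 1.2-fold higher number from compound 1 to compound 3 (0.09 log units; within the scatter)), and it too stays within the scatter, so neither change separates the compounds on this read-out, although the groups that leave and enter differ in their atoms and in their count of hydrogen-bond acceptors. No supporting measurement bears on either step, so neither reading can be tied to a cause.

For the compounds shown here, still open is whether any group at this place produces a step beyond the scatter, since only two aromatic groups with no net charge have been compared there in a one-place step. An aminomethyl or carboxylic acid substituent on that aromatic ring, or a longer alkoxy chain in place of methoxy, would test this in the same read-out.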